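The compounds below may be only part of what the source reports. "The series", "measured", "known", "first", "only" and "open" are said of these compounds alone.

In a functional assay on A549 cells (Homo sapiens) for antiproliferative activity, read by MTT assay, with a stated time of 72 h (a lower number here means a stronger inhibitor, a higher number a weaker inhibitor), compound 2 `O=C1O[C@H]([C@@H](O)Cn2cc(CNS(=O)(=O)c3ccc(F)cc3)nn2)C(OCc2ccccc2)=C1OCc1ccccc1` gives 22500 nM. Compound 3 `O=C1O/C(=C\Cn2cc(-c3cccc(O)c3)nn2)C(OCc2ccccc2)=C1OCc1ccccc1` gives 23300 nM, within the scatter of compound 2. Compound 1 `Cc1ccc(-c2cn(C/C=C3\OC(=O)C(OCc4ccccc4)=C3OCc3ccccc3)nn2)cc1` reads > 100000 nM, which is a limit of the assay. Compound 4 `C[Si](C)(C)c1cn(C[C@H](O)[C@H]2OC(=O)C(OCc3ccccc3)=C2OCc2ccccc2)nn1` follows from compound 2 by a group of 4 heavy atoms (3 carbon, 1 silicon; no ring) in place of a group of 12 heavy atoms (7 carbon, 1 nitrogen, 2 oxygen, 1 fluorine, 1 sulfur; one six-membered aromatic ring of carbon only), on an aromatic carbon. Going by the values given here, the only measured step, an at least 4.2-fold lower number from compound 1 to compound 3 (0.63 log units; beyond the scatter), puts 3-hydroxyphenyl in place of 4-methylphenyl, and neither group takes part in the present change. It therefore bears only loosely, and with the limit of > 100000 nM in this assay, at which 1 of the 3 values shown sits, it suggests a modest expected move toward a weaker number in this assay. The expected step is a 1.6-fold higher number from compound 2 to compound 4 (0.19 log units; within the scatter). For compound 4 the estimate is 35000 nM, with an expected range of 12000 nM to 100000 nM.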

Compound 4, half-maximal inhibitory concentration: 19200 nM
For compound 4 the middle estimate is 1.8-fold (0.26 log units) above the measured one; measured number inside the range.
By their numbers in this assay, from the lowest: compounds 4, 2 and 3 (each within the scatter of the next). At a limit, above all of these: compound 1.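

In this assay, the change on this aromatic carbon of the five-membered ring is a 1.2-fold lower number from compound 2 to compound 4 (0.07 log units; within the scatter). The (((4-fluorophenyl)sulfonyl)amino)methyl group, with its six-membered aromatic ring and its hydrogen-bond donor and acceptors, can therefore be replaced by a ringless group of 4 heavy atoms, with no donor or acceptor, without a change beyond the scatter. No measured property shown bears on this step.

Still open, as far as these compounds go, is whether an amine, a carboxylic acid or a longer alkyl chain on this carbon would move the number beyond the scatter.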